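Compound 1 to compound 3: a smaller amino group

The compounds below may be only part of what the source reports. "The series", "measured", "known", "first", "only" and "open" are said of these compounds alone.

- compound 1 `N=C(NC(=N)NC1CCCC1)Nc1ccc(C(F)(F)F)cc1`: 3800 nM
- compound 2 `CCCCCCCNC(=N)NC(=N)Nc1ccc(F)c(F)c1`: 1800 nM

For the measured compounds named here, in a functional assay on HCT-116 cells (Homo sapiens) for antiproliferative activity, read by MTT assay, with a stated time of 72 h (a lower number here means a stronger inhibitor, a higher number a weaker inhibitor), compound 1 gives 3800 nM, the higher of the two numbers so far. Compound 2 gives 1800 nM, and the gap between the two lies just beyond the scatter. These two compounds differ in more than one place, so their gap says nothing about any single change.

Compound 3 `CCN(C)C(=N)NC(=N)Nc1ccc(C(F)(F)F)cc1` keeps the core of compound 1 and changes one place: ethyl(methyl)amino in place of cyclopentylamino on a carbon with a double bond to nitrogen. In words, this is ethyl(methyl)amino in place of cyclopentylamino on a carbon with a double bond to nitrogen. Going by the values given here, no measured pair isolates this change, so the expectation is a judgement with little support. Among the compounds with values here, its only anchor is compound 1 at 3800 nM, the one measured compound sharing the core of compound 3.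

A step beyond the scatter towards a higher number, meaning a weaker inhibitor, is expected in this assay. The estimated step is a 3.2-fold higher number from compound 1 to compound 3 (0.50 log units; beyond the scatter).

For compound 3 the estimated value is 12000 nM, with an expected range from 4000 nM to 40000 nM.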

Compound 3, half-maximal inhibitory concentration: 4000 nM
Compound 3: middle estimate off by 3.0-fold (0.48 log units), on the high side; the measured number falls inside the stated range.
By their numbers in this assay, from the lowest: compound 2; then compounds 1 and 3 (each within the scatter of the next).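

In this assay, for the compounds shown here, ethyl(methyl)amino in place of cyclopentylamino on a carbon with a double bond to nitrogen gives a 1.1-fold higher number from compound 1 to compound 3 (0.02 log units; within the scatter) and is the first single-place comparison. At this position, on the core of compound 1, the exchange removes the five-membered non-aromatic ring and the hydrogen-bond donor of the leaving group and takes the group from 6 heavy atoms to 4, yet the two compounds remain indistinguishable in this read-out. Nothing available explains why these two compounds cannot be told apart, and this single pair supports no wider rule for the position.

Going by these compounds alone, whether this position accepts other groups just as readily remains open, for example benzylamino, morpholino or a chain ending in a carboxylic acid, since the only two groups compared here are cyclopentylamino and ethyl(methyl)amino. On these data alone, it is also open whether ethyl(methyl)amino in place of cyclopentylamino would read the same way on a different core, as the comparison rests on the core of compound 1 alone.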